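The source may hold more compounds than are shown below. What is called first, only, known or untested is meant among the compounds shown, and "the series" means these compounds.

Measured compounds in an assay on Sf9 cells for inhibition of serine/threonine-protein kinase 4 (Homo sapiens), read by luminescence and ADP-Glo, with a stated time of 1 h, in the presence of a further agent that is not named here; on this read-out higher numbers stand for weaker inhibition and lower numbers for stronger inhibition:

- compound 1 `CCC1C(=O)N(C)c2cnc(Nc3ccc(S(N)(=O)=O)cc3)nc2N1C`: 479 nM
- compound 2 `CCCC1C(=O)N(C)c2cnc(Nc3ccc(S(N)(=O)=O)cc3)nc2N1C`: 206 nM
- compound 3 `CN1C(=O)C(c2cccc(Cl)c2)N(C)c2nc(Nc3ccc(S(N)(=O)=O)cc3)ncc21`: 989 nM

Among these three, compound 3 gives the highest number in this assay; its nearest neighbour is compound 1, with a 2.1-fold higher number from compound 1 to compound 3 (0.31 log units; beyond the scatter), and the widest gap is a 4.8-fold higher number from compound 2 to compound 3 (0.68 log units; beyond the scatter). Compound 4 `CN1C(=O)C(c2ccccc2F)N(C)c2nc(Nc3ccc(S(N)(=O)=O)cc3)ncc21` differs from compound 3 at the saturated ring carbon: 2-fluorophenyl in place of 3-chlorophenyl on a saturated ring carbon.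

The measured steps that touch this ring carbon are a 2.1-fold higher number from compound 1 to compound 3 (0.31 log units; beyond the scatter) and a 4.8-fold higher number from compound 2 to compound 3 (0.68 log units; beyond the scatter); both exchange a short chain for an aryl group, while a 2.3-fold lower number from compound 1 to compound 2 (0.37 log units; beyond the scatter) lengthens the chain only. Going by the values given here, none of them exchanges one substituted phenyl for another, so no measured step speaks directly to the move from compound 3 to compound 4. On that basis the expected change in this assay is none beyond the scatter, with the uncertainty spread to both sides.

Compound 4 is therefore estimated at 1000 nM, in the range 350 nM to 2900 nM. This corresponds to an expected step of a 1.0-fold higher number from compound 3 to compound 4 (0.00 log units; within the scatter).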

Compound 4, half-maximal inhibitory concentration: 75 nM
Estimate against measurement, compound 4: 13-fold (1.12 log units) above, outside the stated range (below it).
By their numbers in this assay, from the lowest: compound 4; then compound 2; then compound 1; then compound 3.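

In this assay, the saturated ring carbon next to the ring nitrogen proves sensitive to which substituted phenyl it carries: the exchange of 3-chlorophenyl for 2-fluorophenyl gives a 13-fold lower number from compound 3 to compound 4 (1.12 log units; beyond the scatter), although both groups have the same count of heavy atoms. The earlier compounds shown here showed an aryl group only giving higher numbers than the short chains, whereas 2-fluorophenyl reverses this, with a 6.4-fold lower number from compound 1 to compound 4 (0.81 log units; beyond the scatter) and a 2.7-fold lower number from compound 2 to compound 4 (0.44 log units; beyond the scatter), so the outcome of replacing a chain with an aryl group depends on the aryl group. Nothing available explains this shift.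

Compound 3 and compound 4 differ in both the halogen and its place on the phenyl ring, so the two changes cannot be separated. From the compounds shown here alone, whether a 2-chlorophenyl, a 3-fluorophenyl or an unsubstituted phenyl would give numbers nearer compound 3 or compound 4 remains open.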